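Two Close Values and a Smaller Fluorinated Group

The compounds below may be only part of what the source reports. "The series", "measured", "known", "first", "only" and "open" are said of these compounds alone.

Compound 1 `CNC(=O)[C@@H](CO)NCc1ccc(OCc2cccc(OC)c2)cc1`: 109 mg/kg
Compound 2 `CNC(=O)[C@@H](CO)NCc1ccc(OCc2ccccc2C(F)(F)F)cc1`: 85.6 mg/kg

Both compounds were tested in a functional assay on the whole organism with Mus musculus as the target; on this read-out lower numbers stand for an effect already at smaller amounts and higher numbers for an effect only at larger amounts of compound. Compound 2, at 85.6 mg/kg, lies within the usual scatter of compound 1, at 109 mg/kg. Compound 3 `CNC(=O)[C@@H](CO)NCc1ccc(OCc2ccccc2F)cc1` has fluoro in place of trifluoromethyl on an aromatic carbon. Going by the values given here, no measured pair here shows a change of this kind, so the data give no direct guide to its size. A shift beyond the scatter is not expected in either direction. The expected step of a 1.1-fold lower number from compound 2 to compound 3 (0.06 log units; within the scatter) is accordingly small. In this assay, compound 3 is estimated at 75 mg/kg, with an expected range from 38 mg/kg to 150 mg/kg.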

Compound 3, dose for half-maximal effect: 12.4 mg/kg
Compound 3: middle estimate off by 6.0-fold (0.78 log units), on the high side; measured number outside the range, below it.
By their numbers in this assay, from the lowest: compound 3; then compounds 2 and 1 (each within the scatter of the next).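

In this assay, the position on the aromatic ring turns out to be sensitive to the group it carries: fluoro in place of trifluoromethyl gives a 6.9-fold lower number from compound 2 to compound 3 (0.84 log units; beyond the scatter), which the two earlier compounds, within the scatter of each other, did not foreshadow. 2-Fluorophenyl in place of 3-methoxyphenyl gives an 8.8-fold lower number from compound 1 to compound 3 (0.94 log units; beyond the scatter). Nothing in the data shown accounts for either step. As far as these compounds go, whether chloro, methyl or plain hydrogen at this place would give a number near that of compound 3 remains open.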